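The source may report more compounds than this note shows. Statements on the series, on what has been measured and on what is new or still open speak of the compounds shown alone.

Of the compounds shown here, three built on one shared core have been measured in a functional assay on OVCAR-3 cells (Homo sapiens) for inhibition, read by sulforhodamine B assay, with a stated time of 48 h, tested at 10 uM; a higher number here means a weaker effect of the compound at the concentration tested, a lower number a stronger effect. Compound 1 `COc1cc2cc(Oc3ccc(NC(=O)Nc4ccccc4)cc3)c(C)nc2cc1OC` gives 67.1%. Compound 2 `COc1cc2cc(Oc3ccc(NC(=O)Nc4ccc(C)cc4)cc3)c(C)nc2cc1OC` gives 113%, so that placing methyl in place of hydrogen on an aromatic carbon reads a number 45.9 percentage points higher from compound 1 to compound 2 (beyond the scatter). Compound 3 `COc1cc2cc(Oc3ccc(NC(=O)Nc4ccc(Cl)c(C(F)(F)F)c4)cc3)c(C)nc2cc1OC` gives -27.3%, the lowest of the three numbers; the nearest of the other two is compound 1, with the step of a number 94.4 percentage points lower from compound 1 to compound 3 (beyond the scatter), and the furthest is compound 2, with the step of a number 140.3 percentage points lower from compound 2 to compound 3 (beyond the scatter).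

Compound 4 `COc1cc2cc(Oc3ccc(NC(=O)Nc4ccc(Cl)c(Cl)c4)cc3)c(C)nc2cc1OC` has not yet been measured in this assay. It differs from compound 3 by chloro in place of trifluoromethyl on an aromatic carbon. For the measured compounds named here, no measured pair isolates exactly this exchange, so the two steps that bear on it are those leading into compound 3: both show that the 4-chloro-3-(trifluoromethyl)phenyl group on the amide-type nitrogen brought the number far down, and compound 4 keeps the chloro while replacing only the trifluoromethyl with a second chloro. Compound 4 is therefore expected to remain near the low end, with the step of a number 17.3 percentage points higher from compound 3 to compound 4 (beyond the scatter) expected to be modest and possibly within the scatter. The estimate for compound 4 is -10%, with a range from -45% to 30%.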

Compound 4, a percentage reported as activity, at one concentration (the size of the read-out at that concentration, not a potency): -10%
Compound 4: the middle estimate sits on the measured number at the digits printed; measured number inside the range.
By their numbers in this assay, from the lowest: compound 3; then compound 4; then compound 1; then compound 2.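

In this assay, the low number at this position does not depend on trifluoromethyl: with chloro on that aromatic carbon, ortho to a chloro group, the 3,4-dichlorophenyl group still reads a number 77.1 percentage points lower from compound 1 to compound 4 (beyond the scatter) against phenyl, and a number 123 percentage points lower from compound 2 to compound 4 (beyond the scatter) against 4-methylphenyl. The exchange of trifluoromethyl for chloro still has a measurable effect, though a smaller one, at a number 17.3 percentage points higher from compound 3 to compound 4 (beyond the scatter), so most of the drop seen with 4-chloro-3-(trifluoromethyl)phenyl is kept when a single chlorine atom replaces the four heavy atoms of trifluoromethyl. Nothing given here explains why these groups differ in this way.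

From the compounds shown here alone, whether a lone chloro or a lone trifluoromethyl on that ring would bring the number down as far remains open, as does what a nitrile or an amine would give on the same aromatic carbon. It is also open whether the order of these compounds would hold at concentrations other than the single one tested.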